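A few compounds are considered here, and "the series" means these few. Any claim that something is new, unique, unknown or untested is made for them only; others in the source may bear on it.

Compounds measured in a functional assay on U-937 cells (Homo sapiens) for cytotoxicity, read by CCK-8 assay, with a stated time of 72 h; on this read-out lower numbers stand for stronger inhibition and higher numbers for weaker inhibition:
- compound 1, `C=CCn1c(=O)/c(=C\c2ccccc2OC)[nH]c(=O)/c1=C\c1ccccc1OC`, 5100 nM
- compound 2, `C=CCn1c(=O)/c(=C\c2ccccc2C(F)(F)F)[nH]c(=O)/c1=C\c1ccccc1OC`, 1500 nM
- compound 3, `C=CCn1c(=O)/c(=C\c2ccc(F)c(Br)c2)[nH]c(=O)/c1=C\c1ccccc1OC`, "not active" (no number reported)

Compound 3 has no single number in this assay; it is reported only as "not active" (no number reported), so it stands apart from compound 1 and compound 2, both of which gave a number. Compound 4, `C=CCn1c(=O)/c(=C\c2ccc(C)cc2)[nH]c(=O)/c1=C\c1ccccc1OC`, differs from compound 3 in one place: 4-methylphenyl in place of 3-bromo-4-fluorophenyl on a double-bonded chain carbon bound to an aromatic carbon.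

Within the data shown here, the one counted step, a 3.4-fold lower number from compound 1 to compound 2 (0.53 log units; beyond the scatter), concerns the other arylidene arm of the shared core and leaves the arm changed here untouched. No measured pair therefore bears directly on the change from compound 3 to compound 4, and the direction of the step cannot be read from the numbers shown. What the data do show is that compound 1 and compound 2, both carrying a substituted phenyl on the arm in question, gave numbers, while compound 3 did not. On that basis compound 4 is expected to return to the range where a number is obtained, though a limit remains a real possibility. The estimate for compound 4 in this assay is 6000 nM, within 1500 nM to 25000 nM.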

Compound 4, half-maximal inhibitory concentration: "not active" (no number reported)
Nothing numeric was reported for compound 4; there is nothing to compare the estimate with.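

Compound 3 and compound 4 are both reported only as "not active", without a number, so no new step can be read from this pair. The compounds shown leave open how far either one lies from the numbers of compound 1 and compound 2, and which groups on this arm give a number. Nothing available here accounts for this result.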